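Aryl swap on the benzyl arm of compound 1

The source may hold more compounds than are shown below. What is called first, only, known or untested is meant among the compounds shown, and "the series" means these compounds.

For the measured compounds named here, compound 1 `CC1CCN(Cc2ccc3nc(NC(=O)N/N=C/c4cn(Cc5ccc(Cl)cc5Cl)c5ccccc45)sc3c2)CC1` gives 3140 nM in a functional assay on MDA-MB-231 cells (Homo sapiens) for cytotoxicity, read by MTT assay, with a stated time of 72 h (on this read-out lower numbers stand for stronger inhibition and higher numbers for weaker inhibition), the highest of the two numbers measured so far; the nearest is compound 2 `CN(C)Cc1ccc2nc(NC(=O)N/N=C/c3cn(Cc4ccc(Cl)cc4Cl)c4ccccc34)sc2c1`, which gives 1410 nM. That pair differs at the saturated chain carbon bound to an aromatic carbon, where a 2.2-fold lower number from compound 1 to compound 2 (0.35 log units; beyond the scatter). Compound 3 `CC1CCN(Cc2ccc3nc(NC(=O)N/N=C/c4cn(Cc5ccc(C(C)(C)C)cc5)c5ccccc45)sc3c2)CC1` is not yet measured and differs from compound 1 elsewhere: 4-(tert-butyl)phenyl in place of 2,4-dichlorophenyl on a saturated chain carbon bound to an aromatic nitrogen. Going by the values given here, no measured step touches this place, so the change from compound 1 to compound 2 gives no guide to size or direction here. Near the value of compound 1, compound 3 is therefore expected at 3000 nM, between 900 nM and 10000 nM. The step of a 1.0-fold lower number from compound 1 to compound 3 (0.02 log units; within the scatter) is an estimate only.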

Compound 3, half-maximal inhibitory concentration: 3880 nM
The estimate for compound 3 lay 1.3-fold (0.11 log units) below the measured number, and the stated range covers the measured number.
By their numbers in this assay, from the lowest: compound 2; then compounds 1 and 3 (each within the scatter of the next).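

At the saturated chain carbon bound to an aromatic nitrogen, 4-(tert-butyl)phenyl in place of 2,4-dichlorophenyl gives a 1.2-fold higher number from compound 1 to compound 3 (0.09 log units; within the scatter) in this assay. This position therefore accepts the loss of both chlorines with a tert-butyl group entering, and the number stays within the scatter. No available evidence explains this outcome.

As far as these compounds go, whether the dimethylamino group of compound 2 would give a similar step alongside 4-(tert-butyl)benzyl remains open. So does the result for an unsubstituted phenyl, a pyridine or a carboxylic acid on this arm.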